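Aziridine nitrile ureas: trimming the urea substituent

The compounds below may be only part of what the source reports. "The series", "measured", "known", "first", "only" and "open" are said of these compounds alone.

Compound 1 `CC(C)(C)NC(=O)N1CC1C#N` is the alkyl urea of the shared core, and in a functional assay on RPMI-8226 cells (Homo sapiens) for inhibition (on this read-out higher numbers stand for weaker inhibition and lower numbers for stronger inhibition), compound 1 gives 120000 nM. Going by the values given here, this is the highest of the three numbers measured so far. The nearest is compound 3 `N#CC1CN1C(=O)Nc1cccnc1`, a pyridyl urea, which in this assay gives 12000 nM, a lower number beyond the scatter. The furthest is compound 2 `N#CC1CN1C(=O)Nc1ccc([N+](=O)[O-])cc1`, a nitrophenyl urea, which in this assay gives 9100 nM, again lower beyond the scatter. Among the compounds with values here, both aryl ureas thus sit well below compound 1, while no step between two measured compounds that differ in a single place is available.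

Compound 4 `CNC(=O)N1CC1C#N` takes the change (methyl in place of tert-butyl on an amide-type nitrogen), a smaller alkyl group in place of the larger one. Within the data shown here, nothing measured speaks to a change of this kind; the only comparisons at hand swap alkyl for aryl. The step from compound 1 to compound 4 is therefore expected to be a 1.3-fold higher number from compound 1 to compound 4 (0.10 log units; within the scatter), that is, none beyond the scatter. For compound 4 the estimate is 150000 nM, with a range from 40000 nM to 500000 nM.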

Compound 4, half-maximal inhibitory concentration: 26000 nM
Compound 4: the middle estimate sits 5.8-fold (0.76 log units) above what was measured; measured number below the stated range.
By their numbers in this assay, from the lowest: compounds 2 and 3 (each within the scatter of the next); then compound 4; then compound 1.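

Methyl in place of tert-butyl on an amide-type nitrogen gives, in this assay, a 4.6-fold lower number from compound 1 to compound 4 (0.66 log units; beyond the scatter), the first single-place step in the series. Going by these compounds alone, the step lies beyond the scatter, so the number at this position responds to a change of alkyl group alone, not only to the swaps of alkyl for aryl that the earlier compounds suggested. Nothing at hand accounts for this step.

On these data alone, two alkyl groups give only two points at this nitrogen, so how the number runs across intermediate sizes remains open, for example with an ethyl or isopropyl group. Also open, as far as these compounds go, is what a longer chain ending in an amine or a carboxylic acid would do at the same position.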